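Adding a Carbamoylmethyl Group to a Ring Amine

The compounds below may be only part of what the source reports. "The series", "measured", "known", "first", "only" and "open" are said of these compounds alone.

Among the measured compounds shown here, compound 1 `COc1cc(C2CCNCC2)ccc1Nc1ncc2ccc(-c3ccccc3N(C)S(C)(=O)=O)n2n1` is the only member of this small set with a number rather than a limit in an in vitro ADME assay on microsomes from liver (Rattus norvegicus, strain Sprague-Dawley) for metabolic stability, using NADPH, with a stated time of 10 min, tested at 0.5 uM (a higher number here means that the compound lasts longer, a lower number that the compound disappears faster), where compound 1 gives 0.367 h. Compound 2 `COc1cc(C2CCN(C[C@@H](C)O)CC2)ccc1Nc1ncc2ccc(-c3ccccc3OC)n2n1` reaches a limit of the assay in this assay, giving > 0.666 h. Compound 3 `COc1cc(C2CCN(C(=O)C3CCN3)CC2)ccc1Nc1ncc2ccc(-c3ccccc3OC)n2n1` likewise reaches a limit in this assay, giving > 0.666 h. For the measured compounds named here, the step that the two limits leave unreadable from compound 2 to compound 3 therefore cannot be read; the two values show only that both compounds sit at the limit of > 0.666 h in this assay, at which 2 of the 3 values shown sit.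

Compound 4 `COc1cc(C2CCN(CC(N)=O)CC2)ccc1Nc1ncc2ccc(-c3ccccc3N(C)S(C)(=O)=O)n2n1` differs from compound 1 by carbamoylmethyl in place of hydrogen on an amine nitrogen in a ring. Going by the values given here, no measured step covers exactly this change. Compound 2 and compound 3 carry other groups on the same ring nitrogen, but they also differ from compound 1 in the group on the outer aromatic ring, and their values are limits, so no size can be taken from them. The expectation for compound 4 in this assay therefore rests on compound 1 alone, and compound 4 is expected to show a step of a 1.4-fold higher number from compound 1 to compound 4 (0.13 log units; within the scatter), which would lie within or close to the usual scatter. Compound 4 is estimated at 0.5 h, with a range from 0.25 h to 1 h.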

Compound 4, half-life: < 0.0834 h
Compound 4: a limit, no number (the forecaster's own chance of this, stated with the estimate: 35%); at least 5.9-fold (0.77 log units) between middle value and limit.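

In this assay, carbamoylmethyl in place of hydrogen on the amine nitrogen in the ring gives an at least 4.4-fold lower number from compound 1 to compound 4 (0.64 log units; beyond the scatter), so at this position the change moves the read-out well past the usual scatter, and towards faster disappearance. The value of compound 4 is a limit and not a number, so the full size of the step stays unknown, and compound 4 stands alone at the low end of the values shown: the limit of < 0.0834 h in this assay, at which 1 of the 4 values shown sits.

Among the compounds shown here, compound 2 and compound 3 also carry groups on this ring nitrogen, but they differ from compound 1 in a second place as well and the step between them cannot be read, so only the pair of compound 1 and compound 4 isolates a change on this nitrogen.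

The compounds shown leave open whether the fall belongs to carbamoylmethyl as such or would also follow from a small group such as methyl on the same nitrogen of the core of compound 1. They also leave open what a carboxylic acid in place of the primary amide, or a longer chain between that amide and the ring nitrogen, would do to the half-life.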